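The compounds below may be only part of what the source reports. "The series", "measured", "known", "first", "only" and "open" are said of these compounds alone.

Working notes on the series. In a functional assay on KBVIN cells (Homo sapiens) for antiproliferative activity, read by sulforhodamine B assay, with a stated time of 3 days (on this read-out higher numbers stand for an effect only at larger amounts of compound and lower numbers for an effect already at smaller amounts), compound 1 `CCCC1=C(OC)C(CCC)(CCC)C(=O)/C(=C(O)\C=C\c2ccccc2)C1=O` gives 3.4 uM and compound 2 `CCCC1=C(OCCC(C)C)C(CCC)(CCC)C(=O)/C(=C(O)\C=C\c2ccccc2)C1=O` gives 19.2 uM. Among the compounds with values here, compound 2 therefore holds the higher of the only two numbers so far, and the gap to compound 1 lies beyond the scatter.

Compound 3 `CCCC1=C(OCC(C)C)C(CCC)(CCC)C(=O)/C(=C(O)\C=C\c2ccccc2)C1=O` differs from compound 2 by isopropyl in place of isobutyl on a saturated chain carbon bound to an oxygen on an unsaturated carbon. This is isopropyl in place of isobutyl on a saturated chain carbon bound to an oxygen on an unsaturated carbon, which reads as isopentyloxy to isobutoxy when cut one bond further out.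

Within the data shown here, only one measured step bears on this change: a 5.6-fold higher number from compound 1 to compound 2 (0.75 log units; beyond the scatter), which put isobutyl in place of hydrogen at the same place. The change to compound 3 takes back only part of that addition, and two compounds cannot show whether the trend runs evenly along the chain. A partial return toward lower numbers is expected in this assay, smaller than the measured step and possibly not clear of the scatter.

The expected change is a 1.7-fold lower number from compound 2 to compound 3 (0.24 log units; within the scatter).

For compound 3 the estimate is 11 uM, with an expected range of 5 uM to 22 uM.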

Compound 3, concentration for half-maximal effect: 4.1 uM
Estimate against measurement, compound 3: 2.7-fold (0.43 log units) above, and the stated range ends above it.
By their numbers in this assay, from the lowest: compounds 1 and 3 (each within the scatter of the next); then compound 2.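

In this assay the rise that came with the isopentyloxy chain does not build evenly along the chain: isopropyl in place of isobutyl on a saturated chain carbon bound to an oxygen on an unsaturated carbon gives a 4.7-fold lower number from compound 2 to compound 3 (0.67 log units; beyond the scatter) and so takes back nearly all of it. At the same place, isopropyl in place of hydrogen gives a 1.2-fold higher number from compound 1 to compound 3 (0.08 log units; within the scatter) and the isobutoxy chain of compound 3 cannot be told apart from the methoxy group of compound 1, which leaves compound 2 as the only one of the three that stands apart. Nothing available explains why the isobutyl and isopropyl groups differ in this way.

Three compounds leave open whether the jump at compound 2 follows chain length or the branching of the isopentyl group, and a straight pentyl chain at the same place would separate the two. Also open, as far as these compounds go, is how this position responds to anything other than a plain carbon chain, such as an amine or a carboxylic acid at the end of the chain.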